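Chloro in place of cyano on an aromatic carbon

This account rests on a few compounds, and the source may have more. Where it says the series, first, only, none or still open, it means among the compounds named here.

In a functional assay on MDA-MB-436 cells (Homo sapiens) for antiproliferative activity, read by MTT assay, with a stated time of 48 h (on this read-out higher numbers stand for weaker inhibition and lower numbers for stronger inhibition), compound 1 (`CN1CCN(c2ccc(-c3cc4c(N5CCN(S(=O)(=O)/C=C/c6ccccc6)CC5)ncnc4s3)cc2)CC1`) gives 8670 nM and compound 2 (`CCCNC(=O)N1CCN(c2ncnc3sc(-c4ccc(N5CCN(C)CC5)cc4)cc23)CC1`) gives 12400 nM while compound 3 (`CN1CCN(c2ccc(-c3cc4c(N5CCN(C(=O)Nc6ccc(C#N)cc6)CC5)ncnc4s3)cc2)CC1`) gives 5010 nM in the same micromolar range. The standing of compound 3 is mixed: the data show a 1.7-fold lower number from compound 1 to compound 3 (0.24 log units; within the scatter) and also a 2.5-fold lower number from compound 2 to compound 3 (0.39 log units; beyond the scatter) so only the second of these gaps clears the scatter.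

Compound 4 (`CN1CCN(c2ccc(-c3cc4c(N5CCN(C(=O)Nc6ccc(Cl)cc6)CC5)ncnc4s3)cc2)CC1`) has chloro in place of cyano on an aromatic carbon, para to a large group (chloro in place of cyano on an aromatic carbon). For the measured compounds named here, no measured step alters a substituent on this ring, so the data hold no direct precedent. The nearest evidence is a 2.5-fold lower number from compound 2 to compound 3 (0.39 log units; beyond the scatter) which exchanges the whole group on the same amide-type nitrogen, and compound 4 keeps the phenyl ring brought in by that step. No step beyond the scatter is therefore expected, and no direction is favoured. In this assay the expected outcome is a 1.1-fold lower number from compound 3 to compound 4 (0.05 log units; within the scatter) as a small shift at most. Compound 4 is estimated at 4500 nM within an expected range from 2200 nM to 9000 nM on present data.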

Compound 4, half-maximal inhibitory concentration: 9270 nM
The estimate for compound 4 lay 2.1-fold (0.31 log units) below the measured number; the measured number lies above the stated range.
By their numbers in this assay, from the lowest: compounds 3, 1, 4 and 2 (each within the scatter of the next, the first and the last beyond it).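

In this assay, for the compounds shown here, the exchange of cyano for chloro on this aromatic carbon, para to a large group, gives a 1.9-fold higher number from compound 3 to compound 4 (0.27 log units; within the scatter), the first direct reading at this position, and it does not clear the scatter. It also qualifies the earlier aryl-for-propyl result: with the 4-cyanophenyl group that exchange gave a 2.5-fold lower number from compound 2 to compound 3 (0.39 log units; beyond the scatter), whereas with 4-chlorophenyl it gives a 1.3-fold lower number from compound 2 to compound 4 (0.13 log units; within the scatter), so only the cyano-bearing version lies beyond the scatter. Against the sulfonyl compound, the chloro compound shows a 1.1-fold higher number from compound 1 to compound 4 (0.03 log units; within the scatter), and nothing measured here accounts for any of these steps.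

Only cyano and chloro are shown on this carbon. The compounds leave open whether the unsubstituted phenyl ring, or a methoxy group, an amine or a carboxylic acid at this place, would give a number beyond the scatter from those of compound 3 and compound 4.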